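Replacing the Formyl Group at the Aryl Position

This account rests on a few compounds, and the source may have more. Where it says the series, first, only, none or still open, it means among the compounds named here.

Measured compounds:
compound 1, `O=Cc1ccc(-c2cn3ccnc3c(-c3ccc4ncn(C5CCCCC5)c4c3)n2)cc1`: 27.8%
compound 2, `c1ccc2c(-c3cn4ccnc4c(-c4ccc5ncn(C6CCCCC6)c5c4)n3)cccc2c1`: 2.3%
compound 3, `CC(=O)c1ccc(-c2cn3ccnc3c(-c3ccc4ncn(C5CCCCC5)c4c3)n2)cc1`: 0.58%

All three share a core and differ only in the aryl group attached to it, and all were tested in a functional assay on SK-MEL-2 cells (Homo sapiens) for inhibition, read by sulforhodamine B assay, with a stated time of 48 h, tested at 10 uM; a lower number here means less inhibition, a higher number more inhibition at the concentration tested (going by the name of the read-out). Compound 1 stands highest of the three. The reading falls a number 25.5 percentage points lower from compound 1 to compound 2 (beyond the scatter) and falls a number 27.2 percentage points lower from compound 1 to compound 3 (beyond the scatter), both beyond the scatter. Between the two lower compounds the gap is a number 1.7 percentage points lower from compound 2 to compound 3 (within the scatter), so compound 2 and compound 3 cannot be told apart.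

Compound 4 is `Fc1ccccc1-c1cn2ccnc2c(-c2ccc3ncn(C4CCCCC4)c3c2)n1`. Its change from compound 1 is 2-fluorophenyl in place of 4-formylphenyl on an aromatic carbon. Both measured steps from compound 1 bear on this: each altered the same aryl group, and each lowered the reading beyond the scatter. Compound 4 changes the aryl group again, so a drop of similar size is expected, landing among the two low compounds. Compound 4 is therefore expected to give about 5%, between -4% and 18%. This corresponds to an expected step of a number 22.8 percentage points lower from compound 1 to compound 4 (beyond the scatter) in this assay.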

Compound 4, a percentage reported as inhibition, at one concentration (the size of the read-out at that concentration, not a potency): 10.5%
For compound 4 the middle estimate is 5.5 percentage points below the measured one; the measured number falls inside the stated range.
By their numbers in this assay, from the lowest: compounds 3, 2 and 4 (each within the scatter of the next); then compound 1.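

Replacing 4-formylphenyl with 2-fluorophenyl lowers the reading in this assay (a number 17.3 percentage points lower from compound 1 to compound 4 (beyond the scatter)), so a third, different aryl group also falls short of compound 1. Compound 4 cannot be told apart from the other two low compounds (a number 9.9 percentage points higher from compound 3 to compound 4 (within the scatter); a number 8.2 percentage points higher from compound 2 to compound 4 (within the scatter)), which leaves 4-formylphenyl alone above 2-fluorophenyl, 4-acetylphenyl and naphthalen-1-yl among the four groups shown at this position. No measurement here explains why compound 1 stands apart.

Still open, going by these compounds, is whether the formyl group itself matters or whether other groups at the same ring position would serve as well, such as a carboxylic acid, a hydroxymethyl or an amine. On these data alone, it is also open whether 4-fluorophenyl would read differently from the 2-fluorophenyl of compound 4.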